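Three Limits and a Nitrile Where Methoxy Groups Stood

The source may hold more compounds than are shown below. What is called first, only, known or untested is meant among the compounds shown, and "the series" means these compounds.

In an assay on HL-60 cells for agonist activity at N-formyl peptide receptor 3 (Homo sapiens), read by calcium flux (a higher number here means that more compound is needed for the effect, a lower number that less compound is needed), none of the three measured compounds gives a number. Compound 1 `COc1ccc(Cc2cc(-c3ccc(C)cc3)nn(CC(=O)Nc3ccc(Br)cc3)c2=O)cc1` reaches only the limit > 50000 nM. Compound 2 `COc1ccc(Cc2cc(-c3ccc(F)cc3)nn(CC(=O)Nc3ccc(Br)cc3)c2=O)cc1` likewise reaches only the limit > 50000 nM. Compound 3 `COc1cc(Cc2cc(C)nn(CC(=O)Nc3ccc(Br)cc3)c2=O)cc(OC)c1` also returns only the limit > 50000 nM. Within the data shown here, the single one-point comparison among them, fluoro in place of methyl on an aromatic carbon, gives a step that the two limits leave unreadable from compound 1 to compound 2, so it reveals nothing about the size of any change. Compound 3 thus stands exactly where the other two stand, at the limit of > 50000 nM in this assay, at which 3 of the 3 values shown sit, with no value to rank it against them.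

The change to compound 4 `Cc1cc(Cc2ccc(C#N)cc2)c(=O)n(CC(=O)Nc2ccc(Br)cc2)n1` is 4-cyanophenyl in place of 3,5-dimethoxyphenyl on a saturated chain carbon bound to an aromatic carbon. No measured step bears on this exchange; the only step shown concerns a different part of the molecule and is itself unreadable. With every measured value sitting at the limit, there is no ground for expecting compound 4 to move in either direction. In this assay the expected step is a number no higher from compound 3 to compound 4 (the limit leaves the size open), meaning no change beyond the scatter. Compound 4 is accordingly expected to give about 50000 nM, with a range from 10000 nM to 200000 nM, and most probably to be reported once more as a limit rather than a number.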

Compound 4, half-maximal effective concentration: > 50000 nM
Compound 4 was reported as a limit; the forecaster's own chance of this, stated with the estimate: 80%; the middle value lies on the limit itself.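

In this assay compound 4 gives > 50000 nM, which is again a limit and not a number. No step can be read from compound 3 to compound 4, as all the compounds stand at the same place: the limit of > 50000 nM in this assay, at which 4 of the 4 values shown sit. The compounds shown leave open whether any of these groups on the shared core can produce a measurable response in this assay.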